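This account rests on a few compounds, and the source may have more. Where it says the series, first, only, none or still open, it means among the compounds named here.

Measured so far:
compound 1 `COc1cc(-c2ccnc3cc(-c4ccc(C)cc4)nn23)cc(OC)c1OC`, 3 nM
compound 2 `COc1cc(-c2ccnc3c(-c4ccc(C)cc4)cnn23)cc(OC)c1OC`, > 10000 nM
compound 3 `COc1ccc(-c2cc3nccc(-c4cc(OC)c(OC)c(OC)c4)n3n2)cc1[N+](=O)[O-]`, > 10000 nM

In a functional assay on A549 cells (Homo sapiens) for inhibition, read by CCK-8 assay, with a stated time of 48 h (a lower number here means a stronger inhibitor, a higher number a weaker inhibitor), compound 1 gives 3 nM. Compound 2 reaches only the limit of this assay at > 10000 nM. Compound 3 likewise sits at the limit of this assay, > 10000 nM, so no number is known for it; it stands together with compound 2 at the limit of > 10000 nM in this assay, at which 2 of the 3 values shown sit, while compound 1 alone gives a measured value.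

The step under consideration leads from compound 3 to compound 4 `COc1ccc(-c2cc3nccc(-c4cc(OC)c(OC)c(OC)c4)n3n2)cc1F`. The change is fluoro in place of nitro on an aromatic carbon. Between the two no measured step exists, so the direction in this assay must be estimated from the change alone. Compound 1 shows that the shared core can give a strong inhibitor; compound 3, carrying the nitro, shows no inhibition up to the limit. The author expects the fluoro to move compound 4 toward a measurable value, a step of an at least 5.0-fold lower number from compound 3 to compound 4 (0.69 log units; beyond the scatter) in the direction of stronger inhibition, though its size cannot be anchored on a number for compound 3. For compound 4 the estimate in this assay is 2000 nM, within a range from 150 nM to 10000 nM.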

Compound 4, half-maximal inhibitory concentration: 545 nM
Beside the measured number, compound 4's estimate is 3.7-fold (0.56 log units) above it, and the stated range covers the measured number.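

Fluoro in place of nitro on an aromatic carbon gives an at least 18-fold lower number from compound 3 to compound 4 (1.26 log units; beyond the scatter) in this assay, so a compound carrying a methoxy group on this ring can give a measurable value, and the position ortho to that methoxy group tolerates at least one substituent. Compound 3 stands at a limit, > 10000 nM, and not at a number, so the true size of this step cannot be read: the limit of > 10000 nM in this assay, at which 2 of the 4 values shown sit.

Even so, the fluoro does not bring back the level of the best compound shown, since 3-fluoro-4-methoxyphenyl in place of 4-methylphenyl gives a 180-fold higher number from compound 1 to compound 4 (2.26 log units; beyond the scatter).

From the compounds shown here alone, this last step changes two things on the ring at once, so it remains open how much of the gap to compound 1 belongs to the fluoro and how much to the methoxy group, and a compound carrying only one of them would separate the two. Going by these compounds, it also remains open how a chloro group, an amine or a hydroxyl group at the place of the fluoro would read in this assay.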